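This account rests on a few compounds, and the source may have more. Where it says the series, first, only, none or still open, it means among the compounds named here.

In a functional assay on PC-3 cells (Homo sapiens) for cytotoxicity (on this read-out lower numbers stand for stronger inhibition and higher numbers for weaker inhibition), compound 3 (`O=C(CCCCC(=O)Nc1nc2ccc([N+](=O)[O-])cc2s1)NO`) gives > 30 ug/mL, which is a limit and not a number. Compound 2 (`CS(=O)(=O)c1ccc2nc(NC(=O)CCCCC(=O)NO)sc2c1`) gives > 30 ug/mL, also a limit. Compound 1 (`COc1ccc2nc(NC(=O)CCCCC(=O)NO)sc2c1`) is the only one of these with a number, at 15.3 ug/mL. Compound 4 (`CCOc1ccc2nc(NC(=O)CCCCC(=O)NO)sc2c1`) departs from compound 3 by this change: ethoxy in place of nitro on an aromatic carbon. For the measured compounds named here, two measured steps bear on it: an at least 1.9-fold higher number from compound 1 to compound 3 (0.29 log units; that floor lies within the scatter), and an at least 1.9-fold higher number from compound 1 to compound 2 (0.29 log units; that floor lies within the scatter). The reverse direction, away from nitro, is therefore expected to give a lower number in this assay, though its size cannot be read from a limit. The expected step is an at least 1.8-fold lower number from compound 3 to compound 4 (0.27 log units; that floor lies within the scatter). For compound 4 the estimated value is 16 ug/mL, with an expected range of 7 ug/mL to 30 ug/mL.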

Compound 4, half-maximal inhibitory concentration: 6.69 ug/mL
Estimate against measurement, compound 4: 2.4-fold (0.38 log units) above; the whole stated range lies above it.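

In this assay, ethoxy at this position gives steps beyond the scatter against both limit compounds: an at least 4.4-fold lower number from compound 3 to compound 4 (0.65 log units; beyond the scatter) and an at least 4.4-fold lower number from compound 2 to compound 4 (0.65 log units; beyond the scatter). For the compounds shown here, the floors against methoxy lay within the scatter, so this is the first clear separation of an ether group from nitro and methylsulfonyl, though both new sizes remain floors set by a limit: the limit of > 30 ug/mL in this assay, at which 2 of the 4 values shown sit. Methoxy to ethoxy also registers, with a 2.3-fold lower number from compound 1 to compound 4 (0.36 log units; beyond the scatter), the first step between two actual numbers.

From the compounds shown here alone, whether a longer chain such as propoxy or butoxy extends this step remains open. Also open, going by these compounds, is how an amine or a carboxylic acid at this position would read.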